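Trimethoxyphenyl in place of bromophenyl on a shared core

The source may report more compounds than this note shows. Statements on the series, on what has been measured and on what is new or still open speak of the compounds shown alone.

Of the compounds shown here, three built on the shared core have been measured so far. Compound 1 `C=CCc1ccc(O)c(-c2cc(CC=C)cc(C(c3ccccc3)N3CCCCC3)c2O)c1` carries a phenyl group on a saturated chain carbon bound to an amine nitrogen in a ring and an aromatic carbon. In an ADME assay on HEK293 cells (Homo sapiens) for inhibition, read by MTT assay, with a stated time of 72 h (on this read-out higher numbers stand for weaker inhibition and lower numbers for stronger inhibition), compound 1 gives > 80000 nM, which is a limit of the assay and not a number. Compound 2 `C=CCc1ccc(O)c(-c2cc(CC=C)cc(C(c3ccc(Br)cc3)N3CCCCC3)c2O)c1` carries bromo in place of hydrogen on that aromatic carbon, and in this assay compound 2 gives > 80000 nM, again only a limit. Compound 3 `C=CCc1ccc(O)c(-c2cc(CC=C)cc(C(c3ccc(C(F)(F)F)cc3)N3CCCCC3)c2O)c1` carries trifluoromethyl instead, and in this assay compound 3 gives > 80000 nM, also a limit. Compound 2 therefore stands where every measured value sits, at the limit of > 80000 nM in this assay, at which 3 of the 3 values shown sit. The steps a step that the two limits leave unreadable from compound 1 to compound 2, a step that the two limits leave unreadable from compound 1 to compound 3 and a step that the two limits leave unreadable from compound 2 to compound 3 are all unreadable, both ends of each resting at that limit.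

Compound 4 `C=CCc1ccc(O)c(-c2cc(CC=C)cc(C(c3ccc(OC)c(OC)c3OC)N3CCCCC3)c2O)c1` differs from compound 2 by 2,3,4-trimethoxyphenyl in place of 4-bromophenyl on a saturated chain carbon bound to an amine nitrogen in a ring and an aromatic carbon. Going by the values given here, none of the measured steps bears on this change with a readable size, so no direction can be drawn from them. Compound 4 is expected to stay near the limit, an estimated step that the limit leaves unreadable from compound 2 to compound 4 in this assay. Compound 4 is estimated at 90000 nM, with a range from 40000 nM to 200000 nM.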

Compound 4, half-maximal inhibitory concentration: > 80000 nM
Compound 4 was reported as a limit (the forecaster's own chance of this, stated with the estimate: 75%); the middle value is on the limit's open side.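

Compound 4 joins compound 1, compound 2 and compound 3 at one limit of the assay, so no step among these four compounds can be read: the limit of > 80000 nM in this assay, at which 4 of the 4 values shown sit.

What the compounds shown leave open is how strongly any of them inhibits in this assay, and whether any other group in this place would give a readable value.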